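A few compounds are considered here, and "the series" means these few. Any claim that something is new, unique, unknown or untested is made for them only; others in the source may bear on it.

Of the compounds shown here, two with the same core have numbers so far in a functional assay on K562 cells (Homo sapiens) for inhibition, read by trypan blue exclusion, with a stated time of 72 h; a lower number here means a stronger inhibitor, a higher number a weaker inhibitor. Compound 1 `O=c1c(S(=O)(=O)c2ccc(F)cc2F)cc2cnc(Nc3ccc4[nH]ccc4c3)nc2n1C1CCCC1` stands higher of the two (compound 1 gives 5000 nM), while compound 2 `Cn1c(=O)c(S(=O)(=O)c2ccc(Cl)cc2)cc2cnc(Nc3ccc4[nH]ccc4c3)nc21` lies lower, beyond the scatter (compound 2 gives 100 nM). These two differ in more than one place, so their gap isolates no single change. Compound 3 `O=c1c(S(=O)(=O)c2ccc(F)cc2F)cc2cnc(Nc3ccc4[nH]ccc4c3)nc2n1C1CC1` keeps the (2,4-difluorophenyl)sulfonyl group of compound 1 but has cyclopropyl in place of cyclopentyl on an aromatic nitrogen. Among the compounds with values here, no measured step shows this change directly. Within the data shown here, the only guide is compound 2 (100 nM), which has a methyl group on that nitrogen, so a moderate move towards a lower number is expected in this assay. The expected step is an estimate only (a 5.0-fold lower number from compound 1 to compound 3 (0.70 log units; beyond the scatter)). For compound 3 the estimated value is 1000 nM, with an expected range from 200 nM to 5000 nM (an uncertain estimate).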

Compound 3, half-maximal inhibitory concentration: 500 nM
Compound 3: middle estimate off by 2.0-fold (0.30 log units), on the high side; measured number inside the range.
By their numbers in this assay, from the lowest: compound 2; then compound 3; then compound 1.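

In this assay, cyclopropyl in place of cyclopentyl on the aromatic nitrogen gives a 10-fold lower number from compound 1 to compound 3 (1.00 log units; beyond the scatter), with the (2,4-difluorophenyl)sulfonyl group held fixed. Within the data shown here, this is the first step here that isolates a single change, and it shows that the group on this nitrogen alone can move the number beyond the scatter, with the smaller of these two carbon rings giving the lower number. No measurement in hand gives a reason for this step.

Compound 2 carries a methyl group on this nitrogen but also has a different sulfonyl group, so it cannot show whether the direction of this step holds for a still smaller group. Going by these compounds, how a longer chain or a chain ending in an amine would behave on this nitrogen remains open.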